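This account rests on a few compounds, and the source may have more. Where it says the series, first, only, none or still open, it means among the compounds named here.

Compound 1 `O=C1C(=O)N(CN(c2ccccc2)c2ccccc2)c2cccc(Cl)c21` and compound 2 `O=C1C(=O)N(CN(c2ccccc2)c2ccccc2)c2ccccc21` have one core in common and differ at a single point: hydrogen in place of chloro on an aromatic carbon. In a functional assay on MCF7 cells (Homo sapiens) for cytotoxicity, read by sulforhodamine B assay, with a stated time of 48 h (a lower number here means a stronger inhibitor of growth, a higher number a weaker inhibitor of growth), compound 1 gives 29700 nM, and in this assay compound 2 gives 23700 nM. The step this change produced was a 1.3-fold lower number from compound 1 to compound 2 (0.10 log units; within the scatter), so removing the chloro left the growth inhibition essentially where it was.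

Compound 3 `Cc1ccc2nc(/N=C3\C(=O)N(CN(c4ccccc4)c4ccccc4)c4cccc(Cl)c43)sc2c1` keeps the chloro of compound 1 but is built on a core that is not the same; the difference between the two cores is not broken down here. In this assay compound 3 gives 24300 nM, a number that stands within the scatter of both compound 2 and compound 1, so the three measured compounds cannot be told apart on this read-out.

Compound 4 `Cc1ccc2nc(/N=C3\C(=O)N(CN(c4ccccc4)c4ccccc4)c4ccccc43)sc2c1` is not yet measured. It relates to compound 3 exactly as compound 2 relates to compound 1: hydrogen in place of chloro on an aromatic carbon. The surroundings of the change are described in the same words in both pairs, so it is the same change, now applied on the core of compound 3. Because the earlier step of a 1.3-fold lower number from compound 1 to compound 2 (0.10 log units; within the scatter) stayed within the scatter, the step from compound 3 to compound 4 is expected to be small as well, about a 1.2-fold lower number from compound 3 to compound 4 (0.08 log units; within the scatter). Compound 4 is therefore estimated at 20000 nM in this assay, with a likely range from 10000 nM to 40000 nM.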

Compound 4, concentration for 50% growth inhibition: 39200 nM
Beside the measured number, compound 4's estimate is 2.0-fold (0.29 log units) below it, within the range that was stated.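

In this assay, putting hydrogen in place of the chloro on the core of compound 3 gives a 1.6-fold higher number from compound 3 to compound 4 (0.21 log units; within the scatter), so on this core too the change stays within the usual scatter of the read-out. Set side by side, the steps on the two cores cannot be told apart: the same change on two cores in this assay, a 1.3-fold lower number (0.10 log units; within the scatter) from compound 1 to compound 2 and a 1.6-fold higher number (0.21 log units; within the scatter) from compound 3 to compound 4, 2.0-fold (0.31 log units) apart, within the scatter of two such steps. Among these compounds, this shows that, in these two pairs, the swap from chloro to hydrogen carries from one core to the other as a change too small to read with confidence; it does not show that the chloro plays no part in other compounds, or that the two cores respond in exactly the same way, since two small steps could hide a slight difference between them.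

The compounds shown hold only chloro or hydrogen on this aromatic carbon, so it remains open whether a different group there, such as a methoxy group, an amine or a carboxylic acid, would produce a step beyond the scatter. From the compounds shown here alone, it also remains open whether a change elsewhere on these molecules, rather than at this carbon, would shift growth inhibition in a way that could be read clearly.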